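A Methyl Enters the Linker of Compound 3

The source may hold more compounds than are shown below. What is called first, only, known or untested is meant among the compounds shown, and "the series" means these compounds.

Compound 1 `O=[N+]([O-])c1cn2c(n1)OC[C@@H](OCC#Cc1ccc(-c3ccc(OC(F)(F)F)cc3)nc1)C2`, compound 2 `O=[N+]([O-])c1cn2c(n1)OC[C@@H](OCC#Cc1cccc(-c3ccc(OC(F)(F)F)cc3)c1)C2` and compound 3 `O=[N+]([O-])c1cn2c(n1)OC[C@@H](OCc1ccc(-c3ccc(OC(F)(F)F)cc3)cc1)C2` were examined in an ADME assay on microsomes from liver (Homo sapiens) for metabolic stability, read by LC-MS, with a stated time of 1 h, tested at 1 uM; on this read-out higher numbers stand for a more stable compound and lower numbers for a less stable compound. Compound 1 gives 93%, compound 2 gives 94%, and compound 3 gives 97%. The three numbers lie within the scatter of one another, so compound 3 stands level with compound 2 and with compound 1 rather than apart from them; its gaps to each of them are inside the usual variation of repeated readings. Compound 4 `CC(O[C@@H]1COc2nc([N+](=O)[O-])cn2C1)c1ccc(-c2ccc(OC(F)(F)F)cc2)cc1` has not yet been measured in this assay. It differs from compound 3 in a single respect: methyl in place of hydrogen on a saturated chain carbon bound to an aromatic carbon and an oxygen on a saturated carbon. Going by the values given here, no measured pair isolates this change, so the expected size of the step rests only on the narrow band the three measured compounds occupy in this assay. A step of a number 5 percentage points lower from compound 3 to compound 4 (within the scatter) from compound 3 to compound 4 is expected, which is to say none beyond the scatter. Compound 4 is estimated to give 92% in this assay, within a range from 78% to 99%.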

Compound 4, percent of the compound remaining in the Homo sapiens assay: 100%
Compound 4: the middle estimate sits 8 percentage points below what was measured; measured number outside the range, above it.
By their numbers in the Homo sapiens assay, from the lowest: compounds 1, 2, 3 and 4 (each within the scatter of the next).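

In the Homo sapiens assay the methyl in place of hydrogen on a saturated chain carbon bound to an aromatic carbon and an oxygen on a saturated carbon gives the first step read at this position, a number 3 percentage points higher from compound 3 to compound 4 (within the scatter) and so nothing beyond the scatter. In a physicochemical assay for solubility, read by HPLC, at pH 7 (a higher number here means a more soluble compound, a lower number a less soluble compound), compound 3 gives 1.2 ug/mL and compound 4 gives 0.84 ug/mL, which is a 1.4-fold lower number from compound 3 to compound 4 (0.15 log units; within the scatter) and shows that the same change also stays inside the scatter on this second read-out. Nothing available bears on the reason for either result.

The compounds shown leave open whether an ethyl group or a hydroxyl group on that same carbon would also stay within the scatter in both read-outs. They also leave open whether the methyl would do the same on the longer chain of compound 1 or compound 2.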